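The source may hold more compounds than are shown below. What is called first, only, known or untested is meant among the compounds shown, and "the series" means these compounds.

Measured so far: compound 1 `COc1ccc(C(=O)OC(CCN(C)C)c2ccc(Cl)cc2)cc1` with 2190 nM; compound 2 `Cc1ccc(C(=O)OC(CCN(C)C)c2ccc(Cl)cc2)cc1` with 2750 nM; compound 3 `Cc1cccc(C(=O)NC(CCN(C)C)c2ccc(Cl)cc2)c1C` with 3630 nM.

All three were tested in an assay on NIH3T3 cells with Urotensin-2 receptor (Homo sapiens) as the target; on this read-out higher numbers stand for an effect only at larger amounts of compound and lower numbers for an effect already at smaller amounts. Compound 2 and compound 1 share a core and differ only in one spot (methoxy in place of methyl on an aromatic carbon). That change made a step of a 1.3-fold lower number from compound 2 to compound 1 (0.10 log units; within the scatter), so the two values are not separated. Compound 3 has a different core from compound 2, and the difference between the two cores is not broken down here; its value lies within the scatter of both others.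

Compound 4 `COc1cccc(C(=O)NC(CCN(C)C)c2ccc(Cl)cc2)c1C` is not yet measured. It is built from compound 3 by the same kind of change (methoxy in place of methyl on an aromatic carbon). The surroundings differ: in compound 1 the new group is para to a large group, whereas in compound 4 it is ortho to a methyl group and meta to a large group, so the earlier step is only a guide to the same kind of change, not the same change.

The earlier step is within the scatter, and on that basis a step of a 1.2-fold lower number from compound 3 to compound 4 (0.08 log units; within the scatter) is expected in this assay. For compound 4 the estimate is 3000 nM, with a plausible range from 1400 nM to 6500 nM.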

Compound 4, half-maximal effective concentration: 4270 nM
For compound 4 the middle estimate is 1.4-fold (0.15 log units) below the measured one; the measured number falls inside the stated range.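

In this assay, putting methoxy in place of methyl on the core of compound 3 made a 1.2-fold higher number from compound 3 to compound 4 (0.07 log units; within the scatter), and this step does not separate from the one seen earlier on another core: the same change on two cores in this assay, a 1.3-fold lower number (0.10 log units; within the scatter) from compound 2 to compound 1 and a 1.2-fold higher number (0.07 log units; within the scatter) from compound 3 to compound 4, 1.5-fold (0.17 log units) apart, within the scatter of two such steps

On the two cores shown, then, the change left the number within the scatter each time, and the two steps agree as far as this read-out can tell. This does not show that the change is without effect throughout the series, since two pairs are few, and neither the opposite directions of the two steps nor the different surroundings of the new group can be read as meaningful.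

The compounds shown leave open whether another group on this aromatic carbon, such as an amine, a carboxylic acid or a hydroxyl, would give a step beyond the scatter. Going by these compounds, it also remains open what a longer chain in place of the methoxy would do on either core.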